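Carbamate and urea analogues at the urotensin-2 receptor

The source may hold more compounds than are shown below. What is called first, only, known or untested is meant among the compounds shown, and "the series" means these compounds.

Measured compounds:
Compound 1, `COc1ccc(NC(=O)OC(CCN(C)C)c2ccc(Cl)cc2)cc1`: in an assay on NIH3T3 cells with Urotensin-2 receptor (Homo sapiens) as the target (on this read-out higher numbers stand for an effect only at larger amounts of compound and lower numbers for an effect already at smaller amounts), compound 1 gives 1660 nM.
Compound 2, `CN(C)CCC(OC(=O)NCc1ccccc1)c1ccc(Cl)cc1`: in this assay compound 2 gives 2140 nM.
Compound 3, `COc1ccc(NC(=O)NC(CCN(C)C)c2ccc(Cl)cc2)cc1`: in this assay compound 3 gives 2000 nM.

Compound 2 differs from compound 1 by benzyl in place of 4-methoxyphenyl on an amide-type nitrogen, and this change gave a 1.3-fold higher number from compound 1 to compound 2 (0.11 log units; within the scatter). Compound 3 carries a core that differs from that of compound 1, but the difference between the two cores is not broken down here. Compound 4, `CN(C)CCC(NC(=O)NCc1ccccc1)c1ccc(Cl)cc1`, is not yet measured; it differs from compound 3 by benzyl in place of 4-methoxyphenyl on an amide-type nitrogen, the same change that leads from compound 1 to compound 2. Since that earlier step stayed within the scatter, a similarly small step is expected here, namely a 1.2-fold higher number from compound 3 to compound 4 (0.08 log units; within the scatter). For compound 4 in this assay the estimated value is 2400 nM, between 1200 nM and 4800 nM.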

Compound 4, half-maximal effective concentration: 2000 nM
Beside the measured number, compound 4's estimate is 1.2-fold (0.08 log units) above it, within the range that was stated.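

In this assay, benzyl in place of 4-methoxyphenyl on an amide-type nitrogen of the urea core gave no change at the digits printed from compound 3 to compound 4 (within the scatter). Set beside the same change on the carbamate core of compound 1, the two steps do not differ: the same change on two cores in this assay, a 1.3-fold higher number (0.11 log units; within the scatter) from compound 1 to compound 2 and no change at the digits printed (within the scatter) from compound 3 to compound 4, 1.3-fold (0.11 log units) apart, within the scatter of two such steps This shows that, on these two cores, the change left the number within the scatter; it does not show that the change would behave the same way on any other core, and two such small steps cannot reveal a modest dependence on the core.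

The compounds shown leave open what a longer chain such as phenethyl would do on that nitrogen. They also leave open whether a cyclic amine such as pyrrolidine could stand in place of the dimethylamino group.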